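The source may hold more compounds than are shown below. What is called first, only, known or untested is meant among the compounds shown, and "the series" means these compounds.

Going by the values given here, compound 1 `COc1ccc(C(=O)Nc2cccc(-c3oc4cc(-c5ccc(F)cc5)ccc4c(=O)c3O)c2)cc1` gives 8420 nM in a functional assay on HepG2 cells (Homo sapiens) for antiproliferative activity, read by CCK-8 assay, with a stated time of 72 h (on this read-out lower numbers stand for stronger inhibition and higher numbers for weaker inhibition), the lowest of the three numbers measured so far. Compound 2 `O=C(Nc1cccc(-c2oc3cc(-c4ccc(F)cc4)ccc3c(=O)c2O)c1)c1ccc(C(F)(F)F)cc1` gives 42700 nM, and compound 3 `Cc1cc(C)cc(C(=O)Nc2cccc(-c3oc4cc(-c5ccc(F)cc5)ccc4c(=O)c3O)c2)c1` gives 13400 nM. Compound 4 `O=C(Nc1cccc(-c2oc3cc(-c4ccc(F)cc4)ccc3c(=O)c2O)c1)c1cc(F)cc(F)c1` differs from compound 1 by 3,5-difluorophenyl in place of 4-methoxyphenyl on a carbonyl carbon. Among the compounds with values here, two measured steps bear on this change. Exchanging the same group for 3,5-dimethylphenyl gave a 1.6-fold higher number from compound 1 to compound 3 (0.20 log units; within the scatter), whereas the step to trifluoromethyl in place of methoxy gave a 5.1-fold higher number from compound 1 to compound 2 (0.71 log units; beyond the scatter). The change in compound 4 shares features of both steps, so a rise in the number between the within-scatter and the modest case is expected in this assay. Compound 4 is therefore estimated at 16000 nM, with a range of 6000 nM to 45000 nM. That estimate corresponds to an expected step of a 1.9-fold higher number from compound 1 to compound 4 (0.28 log units; within the scatter).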

Compound 4, half-maximal inhibitory concentration: 4960 nM
Estimate against measurement, compound 4: 3.2-fold (0.51 log units) above; measured number below the stated range.
By their numbers in this assay, from the lowest: compounds 4, 1 and 3 (each within the scatter of the next, the first and the last beyond it); then compound 2.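

In this assay, 3,5-difluorophenyl on this carbonyl carbon cannot be told apart from 4-methoxyphenyl, with a 1.7-fold lower number from compound 1 to compound 4 (0.23 log units; within the scatter). Going by these compounds alone, the identity of the groups still matters at this position: 3,5-difluorophenyl against 3,5-dimethylphenyl gives a 2.7-fold lower number from compound 3 to compound 4 (0.43 log units; beyond the scatter), and against 4-(trifluoromethyl)phenyl gives an 8.6-fold lower number from compound 2 to compound 4 (0.93 log units; beyond the scatter), the widest gap so far. Nothing available accounts for these differences. Open, from the compounds shown here alone, is how this position responds to an amine or a carboxylic acid on the phenyl ring, or to a longer chain in place of that ring.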